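The compounds below may be only part of what the source reports. "The series", "measured", "known", "first", "only" and "open" are said of these compounds alone.

Compound 1 `Clc1ccc(-c2cc(-c3cccnc3)nc(-c3ccsc3)c2)o1` stands, together with compound 2 `Clc1ccc(-c2cc(-c3ccoc3)cc(-c3cccs3)n2)cc1`, at the lowest of the three numbers on hand: in an assay on isolated protein for inhibition of DNA topoisomerase 1 (Homo sapiens), tested at 100 uM (on this read-out lower numbers stand for a weaker effect and higher numbers for a stronger effect at the one concentration tested), compound 1 gives 0%, compound 2 gives 0%, and compound 3 `Clc1ccc(-c2cc(-c3ccc(Cl)o3)cc(-c3cccs3)n2)cc1` gives 38.9%. Going by the values given here, the single measured step, a number 38.9 percentage points higher from compound 2 to compound 3 (beyond the scatter), concerns a different group and so does not test the change that leads to compound 4 `Clc1ccc(-c2cc(-c3ccc(Cl)o3)cc(-c3ccsc3)n2)cc1`, in which (4-chlorophenyl in place of pyridin-3-yl on an aromatic carbon). Compound 4 does, however, share the 5-chlorofuran-2-yl group with compound 3, which gave 38.9% in this assay. On that basis compound 4 is expected to rise, a number 25 percentage points higher from compound 1 to compound 4 (beyond the scatter). Without a direct precedent for the change itself, compound 4 is estimated at 25%, in a range from 0% to 50%.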

Compound 4, a percentage reported as inhibition, at one concentration (the size of the read-out at that concentration, not a potency): 29.8%
Beside the measured number, compound 4's estimate is 4.8 percentage points below it, within the range that was stated.
By their numbers in this assay, from the lowest: compounds 1 and 2 (each within the scatter of the next); then compounds 4 and 3 (each within the scatter of the next).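

In this assay, with the 5-chlorofuran-2-yl group held in place, 4-chlorophenyl in place of pyridin-3-yl gives a number 29.8 percentage points higher from compound 1 to compound 4 (beyond the scatter), so this position next to the ring nitrogen affects the read-out and the 5-chlorofuran-2-yl group alone does not secure an effect. Thiophen-3-yl in place of thiophen-2-yl gives a number 9.1 percentage points lower from compound 3 to compound 4 (within the scatter), so that change cannot be told from scatter. Nothing on hand accounts for either result. Still open, going by these compounds, is whether the rise depends on the chlorine of the 4-chlorophenyl group. On these data alone, how a phenyl ring carrying an amine or a carboxylic acid would read at this position also remains open.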